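The compounds below may be only part of what the source reports. "The series", "measured", "known", "first", "only" and "open" are said of these compounds alone.

Measured in a functional assay on Jurkat cells (Homo sapiens) for cytotoxicity, with a stated time of 72 h (a lower number here means that less compound is needed, a higher number that more compound is needed for the effect), all three entries being limits:
Compound 1 `C=C[C@@](C)(/C=C/c1ccc(O)cc1)CCC(O)C(C)(C)O`: > 49000 nM
Compound 2 `C=C[C@@](C)(/C=C/c1ccc(O)cc1)CCC=O`: > 49000 nM
Compound 3 `C=C[C@@](C)(/C=C/c1ccc(O)cc1)CC/C=C/C#N`: > 49000 nM

Compound 3 stands at > 49000 nM, which is a limit of the assay and not a number. The series as a whole offers only (the limit of > 49000 nM in this assay, at which 3 of the 3 values shown sit), so compound 3 has no measured rank against the other two.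

Next comes compound 4 `C=C[C@@](C)(/C=C/c1ccc(O)cc1)CC/C=C(\C)C=O`, with the change (2-formylprop-1-en-1-yl in place of 2-cyanoethenyl on a saturated chain carbon, three bonds along the chain from two double-bonded chain carbons). In words, 2-formylprop-1-en-1-yl takes the place of 2-cyanoethenyl on a saturated chain carbon, three bonds along the chain from two double-bonded chain carbons.

Within the data shown here, three measured steps bear on this, as each exchanges the group at that same place: a step that the two limits leave unreadable from compound 1 to compound 2, a step that the two limits leave unreadable from compound 1 to compound 3 and a step that the two limits leave unreadable from compound 2 to compound 3. None has a readable size, so none supplies a size or direction to carry over. In this assay, no exchange at this place has yet given a numerical value. The expectation is therefore for no step beyond the scatter, with compound 4 most likely reported as a limit again. The expected step is a step that the limit leaves unreadable from compound 3 to compound 4, and its size stays loose. Compound 4 is estimated at 55000 nM, with an expected range of 20000 nM to 100000 nM.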

Compound 4, half-maximal effective concentration: > 49000 nM
Compound 4 gave a limit, no number; the forecaster's own chance of this, stated with the estimate: 75%; the middle value lies beyond the limit too.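

In this assay the steps from compound 1, compound 2 and compound 3 to compound 4 cannot be read, because every value is a limit and not a number: the limit of > 49000 nM in this assay, at which 4 of the 4 values shown sit.

The compounds shown leave open whether any group on this saturated chain carbon gives a numerical value in this assay, and how such groups would rank.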